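Trimming a Long Chain One Carbon Further

The compounds below may be only part of what the source reports. "The series", "measured", "known", "first", "only" and "open" are said of these compounds alone.

Measured compounds in a functional assay on P388 cells (Mus musculus) for cytotoxicity, read by MTT assay; a lower number here means a stronger inhibitor, a higher number a weaker inhibitor:
Compound 1, `CCCCCCCCCCCCCCC/C=C/[C@@H](O)C(=O)N[C@@H](CO[C@@H]1O[C@H](CO)[C@@H](O)[C@H](O)[C@H]1O)[C@H](O)/C=C/CC/C=C(\C)CCCCCCCC`, gives > 50000 nM, a limit of the assay.
Compound 2, `CCCCCCCCCCCCCCC/C=C/[C@@H](O)C(=O)N[C@@H](CO[C@@H]1O[C@H](CO)[C@@H](O)[C@H](O)[C@H]1O)[C@H](O)/C=C/CC/C=C(\C)CCCCCC`, gives > 50000 nM, a limit of the assay.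

Compound 2 stands at the limit of this assay: its value is not a number but the edge of what the assay can report. For the measured compounds named here, the only other value shown, that of compound 1, sits at that same limit (the limit of > 50000 nM in this assay, at which 2 of the 2 values shown sit). The step that the two limits leave unreadable from compound 1 to compound 2 therefore cannot be read, since both of its ends are limits.

Compound 3, `CCCCCCCCCCCCCCC/C=C/[C@@H](O)C(=O)N[C@@H](CO[C@@H]1O[C@H](CO)[C@@H](O)[C@H](O)[C@H]1O)[C@H](O)/C=C/CC/C=C(\C)CCCCC`, has not yet been measured. It differs from compound 2 by hydrogen in place of methyl on a saturated chain carbon, five bonds along the chain from a double-bonded chain carbon. The step from compound 1 to compound 2 is the only measured one that bears on this change, being a shortening of the same chain, and its size is unreadable. So no step beyond the scatter can be foreseen in this assay in either direction, and the most likely outcome is another limit. Compound 3 is expected to give 80000 nM, within 20000 nM to 300000 nM. The step that the limit leaves unreadable from compound 2 to compound 3 is expected to stay within the scatter.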

Compound 3, half-maximal inhibitory concentration: > 50000 nM
Compound 3 ended at the assay's limit; the forecaster's own chance of this, stated with the estimate: 80%; the middle value is on the limit's open side.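

In this assay compound 3 also gives a limit and not a number, so none of the steps linking compound 1, compound 2 and compound 3 can be read: the limit of > 50000 nM in this assay, at which 3 of the 3 values shown sit.

The compounds shown leave open how far past that limit each one lies, and whether any length of this chain would give a measurable value.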